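Arylpropanamide series: a chloro step on the amine-side ring

The source may report more compounds than this note shows. Statements on the series, on what has been measured and on what is new or still open speak of the compounds shown alone.

Measured compounds:
- compound 1, `CC(C)Cc1ccc(C(C)C(=O)NCc2ccc(Cl)cc2)cc1`: in an assay on brain for inhibition of Fatty-acid amide hydrolase 1 (Rattus norvegicus), read by scintillation counting, with a stated time of 10 min (on this read-out lower numbers stand for stronger inhibition and higher numbers for weaker inhibition), compound 1 gives 27000 nM
- compound 2, `CC(C)Cc1ccc(C(C)C(=O)NCc2ccc(Cl)cc2Cl)cc1`: compound 2 gives 21000 nM
- compound 3, `CC(C)Cc1ccc(C(C)C(=O)N2CCN(c3ccccc3)CC2)cc1`: compound 3 gives 4700 nM

Compounds 1 and 2 share a core and differ in one place, (chloro in place of hydrogen on an aromatic carbon). The step of a 1.3-fold lower number from compound 1 to compound 2 (0.11 log units; within the scatter) is small and does not separate the two values. Compound 3 carries a different amide portion; the difference between its core and that of compound 1 is not broken down here. Its value stands lowest of the three, and its distances to compound 2 and to compound 1 both lie beyond the scatter, so compound 3 is the most potent of the measured set.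

Compound 4, `CC(C)Cc1ccc(C(C)C(=O)N2CCN(c3cccc(Cl)c3)CC2)cc1`, is not yet measured. It differs from compound 3 by chloro in place of hydrogen on an aromatic carbon. Among the compounds with values here, this is the same kind of change as the one from compound 1 to compound 2, but the surroundings differ: in the earlier pair the chloro enters ortho to a large group and meta to a chloro group, whereas in compound 4 it enters meta to a large group, phenyl to 3-chlorophenyl. Because the earlier instance of this change gave only a 1.3-fold lower number from compound 1 to compound 2 (0.11 log units; within the scatter), the expected step of a 1.3-fold lower number from compound 3 to compound 4 (0.13 log units; within the scatter) in this assay is likewise small, resting on a single precedent in a different core. Compound 4 is therefore estimated at 3500 nM, with a likely range from 1200 nM to 10000 nM.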

Compound 4, half-maximal inhibitory concentration: 1700 nM
For compound 4 the middle estimate is 2.1-fold (0.31 log units) above the measured one; measured number inside the range.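

In this assay, chloro in place of hydrogen on an aromatic carbon gives a 2.8-fold lower number from compound 3 to compound 4 (0.44 log units; beyond the scatter), a modest step, and set beside the earlier instance of the same change it cannot be told apart from that step: the same change on two cores in this assay, a 1.3-fold lower number (0.11 log units; within the scatter) from compound 1 to compound 2 and a 2.8-fold lower number (0.44 log units; beyond the scatter) from compound 3 to compound 4, 2.2-fold (0.33 log units) apart, within the scatter of two such steps. Within the data shown here, the change therefore carries from one core to the other without any resolved difference in size, even though only the step on the core of compound 3 stands clear of the scatter on its own; that contrast alone does not establish that this core responds more strongly. Two pairs are a thin basis, and they show no general rule, nor can they separate the effect of the core from that of the chloro's different surroundings in each pair.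

The compounds shown leave open whether methyl, methoxy or trifluoromethyl in place of the chloro in the 3-chlorophenyl of compound 4 would give a step of similar size. They also leave open how a chloro elsewhere on the phenyl of compound 3, or a second chloro on the 3-chlorophenyl of compound 4, would read in this assay.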